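This account rests on a few compounds, and the source may have more. Where it says the series, first, only, none or still open, it means among the compounds named here.

Among the compounds with values here, compound 2 `CN(CCN1CCCCC1)c1ccc(Cn2c(=O)[nH]c3c(N)nc(C(F)(F)F)cc32)cn1` gives 25 mL.min-1.g-1 in an in vitro ADME assay on microsomes from liver (Homo sapiens) for pharmacokinetics (a higher number here means faster removal of the compound, a lower number slower removal), the only plain number so far. Compound 1 `Nc1nc(C(F)(F)F)cc2c1[nH]c(=O)n2Cc1ccc(NCCO)nc1` reports a limit of the assay, < 8 mL.min-1.g-1. Within the data shown here, the one measured step, an at least 3.1-fold higher number from compound 1 to compound 2 (0.49 log units; beyond the scatter), is read against (the limit of < 8 mL.min-1.g-1 in this assay, at which 1 of the 2 values shown sits). Compound 3 `CN1CCN(CCN(C)c2ccc(Cn3c(=O)[nH]c4c(N)nc(C(F)(F)F)cc43)cn2)CC1` carries 4-methylpiperazin-1-yl in place of piperidin-1-yl on a saturated chain carbon, two bonds along the chain from a nitrogen on an aromatic ring. Among the measured compounds shown here, no measured step covers that change, since the only step measured moved a different group; the step of no change at the digits printed from compound 2 to compound 3 (within the scatter) is therefore expected to stay within the scatter. The estimate for compound 3 in this assay is 25 mL.min-1.g-1, with a range from 12 mL.min-1.g-1 to 50 mL.min-1.g-1.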

Compound 3, intrinsic clearance in microsomes: 25 mL.min-1.g-1
Beside the measured number, compound 3's estimate shows no gap at the digits printed, and the stated range covers the measured number.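

Putting 4-methylpiperazin-1-yl in place of piperidin-1-yl on a saturated chain carbon, two bonds along the chain from a nitrogen on an aromatic ring, gives no change at the digits printed from compound 2 to compound 3 (within the scatter) in this assay. The methyl(2-(4-methylpiperazin-1-yl)ethyl)amino group gives an at least 3.1-fold higher number from compound 1 to compound 3 (0.49 log units; beyond the scatter), a step of the same printed size as with the piperidin-1-yl chain. That size is only a bound, as compound 1 stands at a limit of the assay: the limit of < 8 mL.min-1.g-1 in this assay, at which 1 of the 3 values shown sits.

Going by these compounds, whether a morpholine ring or a dimethylamino group at the chain end, or a longer chain, would give the same read-out stays open. No compound shown carries the terminal ring without the methyl on the chain nitrogen, or that methyl without the terminal ring. The data do not split the step between these two changes.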